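Predicting a primary amine on the shared piperidine-free core

The source may report more compounds than this note shows. Statements on the series, on what has been measured and on what is new or still open speak of the compounds shown alone.

Measured so far:
Compound 1 `COc1ccc2ncnc(N3CCC(CCNS(N)(=O)=O)CC3)c2c1`: 71%
Compound 2 `COc1cc2ncnc(N3CCC(CCNC(C)=O)CC3)c2cc1OC`: 9%
Compound 3 `COc1cc2ncnc(N3CCC(CO)CC3)c2cc1OC`: 11%

In an assay on cells for inhibition of Ectonucleotide pyrophosphatase/phosphodiesterase family member 1 (Homo sapiens), with a stated time of 60 min, tested at 1 uM (on this read-out lower numbers stand for less inhibition and higher numbers for more inhibition at the one concentration tested (going by the name of the read-out)), compound 1 gives 71%, compound 2 gives 9% and compound 3 gives 11%. Compound 3 thus stands second of the three; its value sits within the scatter of compound 2 and far below compound 1, whose number lies beyond the scatter above it. Compound 1, however, differs from compound 3 in more than one place, so its gap cannot be tied to a single change.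

The unmeasured compound 4 `COc1cc2ncnc(N3CCC(CCN)CC3)c2cc1OC` differs from compound 3 by aminomethyl in place of hydroxy on a saturated chain carbon bound to a saturated ring carbon. Within the data shown here, the only measured step at this same place, a number 2 percentage points higher from compound 2 to compound 3 (within the scatter), was within the scatter, so exchanging one small donor-bearing group for another on this chain has so far left this assay essentially unchanged. On that basis compound 4 is expected to give a number close to compound 3, with the step of a number 7 percentage points higher from compound 3 to compound 4 (within the scatter) not expected to exceed the scatter. Among the measured compounds shown here, the estimate for compound 4 is therefore 18%, with a range from 5% to 45% to allow for the single precedent.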

Compound 4, a percentage reported as inhibition, at one concentration (the size of the read-out at that concentration, not a potency): 45%
Estimate against measurement, compound 4: 27 percentage points below; the measured number falls inside the stated range.
By their numbers in this assay, from the lowest: compounds 2 and 3 (each within the scatter of the next); then compound 4; then compound 1.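

In this assay, aminomethyl in place of hydroxy on a saturated chain carbon bound to a saturated ring carbon gives a number 34 percentage points higher from compound 3 to compound 4 (beyond the scatter), so this position does respond to what is placed there, something a number 2 percentage points higher from compound 2 to compound 3 (within the scatter) could not reveal. Hydrogen in place of acetyl on an amine nitrogen gives a number 36 percentage points higher from compound 2 to compound 4 (beyond the scatter); this change leaves the chain itself in place, so the chain alone does not carry the higher number, and the rise appears only when the acetyl is gone from the nitrogen. Nothing available explains why the uncapped amine gives more inhibition in this assay than the acetamide or the alcohol.

The compounds shown leave open how a methyl group on the amine nitrogen, a longer chain ending in the amine, or a carboxylic acid in the amine's place would read in this assay. On these data alone, compound 1 differs from compound 4 in more than one place, so it also remains open whether its end group, its core or both set its number apart.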